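A few compounds are considered here, and "the series" means these few. Any claim that something is new, unique, unknown or untested is made for them only; others in the source may bear on it.

Series notes. Of the two numbers measured in a functional assay on Molt4/C8 cells (Homo sapiens) for cytotoxicity (a higher number here means a weaker inhibitor, a lower number a stronger inhibitor), compound 1 `Cc1ccc(NC(=O)/C=C/C(=O)N2C/C(=C\c3ccccc3)C(=O)/C(=C/c3ccccc3)C2)cc1` holds the lowest, 660 nM; compound 2 `Cc1ccc(NC(=O)/C=C/C(=O)N2C/C(=C\c3ccc([N+](=O)[O-])cc3)C(=O)/C(=C/c3ccc([N+](=O)[O-])cc3)C2)cc1` with 700 nM lies within the scatter of it, so no difference can be read between the two. The unmeasured compound 3 `O=C(/C=C/C(=O)N1C/C(=C\c2ccccc2)C(=O)/C(=C/c2ccccc2)C1)Nc1ccc(Cl)cc1` differs from compound 1 only by chloro in place of methyl on an aromatic carbon; the shared core of compound 1 is kept. Going by the values given here, no step of this kind has been measured in the set, so the change is expected to shift this assay by a step of a 1.1-fold lower number from compound 1 to compound 3 (0.04 log units; within the scatter), nothing beyond the scatter. Compound 3 is accordingly estimated at 600 nM, within a range of 250 nM to 1500 nM.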

Compound 3, half-maximal inhibitory concentration: 1800 nM
The estimate for compound 3 lay 3.0-fold (0.48 log units) below the measured number, and the stated range ends below it.
By their numbers in this assay, from the lowest: compounds 1 and 2 (each within the scatter of the next); then compound 3.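

In this assay chloro in place of methyl on the aromatic carbon gives a 2.7-fold higher number from compound 1 to compound 3 (0.44 log units; beyond the scatter) and so shows that this place, para to a large group, answers to the exchange of a single heavy atom. The earlier compounds shown here carried no change confined to this group and could not show that. Nothing at hand bears on why the number moves.

Open, from the compounds shown here alone, is whether the step is peculiar to chloro or extends to other groups here. Compounds with fluoro, methoxy or an amine at this place are not among those shown.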